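A few compounds are considered here, and "the series" means these few. Any claim that something is new, unique, unknown or untested is made for them only; others in the source may bear on it.

Three members of the series have been run in a toxicity assay on GES1 cells (Homo sapiens) for inhibition, read by MTT assay, with a stated time of 72 h; on this read-out higher numbers stand for weaker inhibition and lower numbers for stronger inhibition. Compound 1 `COc1ccc(N2CCCC2)c(C(=O)Nc2ccc(CNC(=O)OCc3cccnc3)cc2)c1` gives only a limit of the assay, > 100000 nM. Compound 2 `O=C(NCc1ccc(NC(=O)c2cccc(F)c2N2CCCC2)cc1)OCc1cccnc1` likewise gives only a limit, > 100000 nM. Compound 3 `O=C(NCc1ccc(NC(=O)c2cc(Br)ccc2N2CCCC2)cc1)OCc1cccnc1` also returns a limit, > 100000 nM. For the measured compounds named here, the one step that joins two measured compounds, bromo in place of methoxy on an aromatic carbon, is a step that the two limits leave unreadable from compound 1 to compound 3, so its size cannot be read. Going by the values given here, every value so far sits at the limit of > 100000 nM in this assay, at which 3 of the 3 values shown sit. Compound 2 thus stands at the limit together with the other two, and no number separates them.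

Compound 4 `Cc1cccc(C(=O)Nc2ccc(CNC(=O)OCc3cccnc3)cc2)c1N1CCCC1` is not yet measured. Its difference from compound 2 is methyl in place of fluoro on an aromatic carbon. Among the compounds with values here, no measured step bears on this change: the only step known, from methoxy to bromo, is unreadable, and the three values shown give no spread in this assay from which a size could be drawn. The expectation is therefore no step beyond the scatter, and compound 4 is most likely to return a limit as well. The expected step is a number no higher from compound 2 to compound 4 (the limit leaves the size open). Compound 4 is estimated at 100000 nM, within 50000 nM to 200000 nM in this assay, with a limit the more probable outcome.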

Compound 4, half-maximal inhibitory concentration: > 100000 nM
Compound 4: a limit, no number (the forecaster's own chance of this, stated with the estimate: 85%); the middle value lies on the limit itself.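

Compound 4 gives only a limit in this assay, > 100000 nM. Compound 2 also stands at a limit, so no step can be read between compound 2 and compound 4: the limit of > 100000 nM in this assay, at which 4 of the 4 values shown sit.

The compounds shown leave open whether any substituent on the shared core gives a readable value here, and how these substituents would rank.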